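Working notes: replacing 3-hydroxyphenyl with 2-methylphenyl

A few compounds are considered here, and "the series" means these few. Any claim that something is new, unique, unknown or untested is made for them only; others in the source may bear on it.

Values in a functional assay on OVCAR-3 cells (Homo sapiens) for inhibition, read by MTT assay, with a stated time of 24 h; a lower number here means a stronger inhibitor, a higher number a weaker inhibitor:
- compound 1 `CC1(C)[C@H]2CC[C@]1(C)N(Cc1cn(-c3cccc(C#N)c3)nn1)C(=O)C2`: 230 nM
- compound 2 `CC1(C)[C@H]2CC[C@]1(C)N(Cc1cn(-c3cccc(Cl)c3)nn1)C(=O)C2`: 50 nM
- compound 3 `CC1(C)[C@H]2CC[C@]1(C)N(Cc1cn(-c3cccc(O)c3)nn1)C(=O)C2`: 370 nM

Compound 3 stands with compound 1 at the weak end of this small set. The gap between them is small, a 1.6-fold higher number from compound 1 to compound 3 (0.21 log units; within the scatter). Compound 2 stands clear of both, with a 7.4-fold higher number from compound 2 to compound 3 (0.87 log units; beyond the scatter) the largest step measured, followed by a 4.6-fold lower number from compound 1 to compound 2 (0.66 log units; beyond the scatter).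

Compound 4 `Cc1ccccc1-n1cc(CN2C(=O)C[C@@H]3CC[C@@]2(C)C3(C)C)nn1` carries a new aromatic group: 2-methylphenyl in place of 3-hydroxyphenyl on an aromatic nitrogen. Going by the values given here, no measured compound carries 2-methylphenyl, so these steps are only a loose guide. Both steps involving compound 2 suggest that the aromatic group can move the number by a modest amount. A modest step towards a lower number is expected in this assay. The expected change is a 2.8-fold lower number from compound 3 to compound 4 (0.45 log units; beyond the scatter). For compound 4 the estimate is 130 nM, with an expected range of 40 nM to 400 nM.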

Compound 4, half-maximal inhibitory concentration: 150 nM
For compound 4 the middle estimate is 1.2-fold (0.06 log units) below the measured one, within the range that was stated.
By their numbers in this assay, from the lowest: compound 2; then compounds 4, 1 and 3 (each within the scatter of the next, the first and the last beyond it).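

On the aromatic nitrogen, 2-methylphenyl, with no hydrogen-bond donor or acceptor, gives a lower number than 3-hydroxyphenyl (a 2.5-fold lower number from compound 3 to compound 4 (0.39 log units; beyond the scatter)) in this assay. It cannot be separated from 3-cyanophenyl (a 1.5-fold lower number from compound 1 to compound 4 (0.19 log units; within the scatter)), whereas 3-chlorophenyl keeps a clear lead (a 3.0-fold higher number from compound 2 to compound 4 (0.48 log units; beyond the scatter)), so a donor-free aromatic group does not by itself match compound 2. From the compounds shown here alone, how an amine or a carboxylic acid on this phenyl ring would compare remains open. No measurement shown gives a cause for these steps.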